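Bromo in Place of Fluoro, Measured Twice, Expected Once

A few compounds are considered here, and "the series" means these few. Any claim that something is new, unique, unknown or untested is made for them only; others in the source may bear on it.

Three compounds were measured in a functional assay on HEp-2 cells (Homo sapiens) for cytotoxicity, read by MTT assay, with a stated time of 72 h, tested at 1.25 ug/mL; a lower number here means less inhibition of growth, a higher number more inhibition of growth at the concentration tested:
compound 1, `O=C1NC(=S)/C(=C/c2ccc(Br)cc2)S1`, gives -3.16%
compound 2, `O=C1NC(=S)/C(=C/c2cccc(F)c2)S1`, gives 0.84%
compound 3, `O=C1NC(=S)/C(=C/c2ccc(F)cc2)S1`, gives -10.8%

Compound 2 stands highest of the three numbers; its nearest neighbour is compound 1, within the scatter, and its furthest is compound 3, beyond the scatter. How the core of compound 2 differs from the core of compound 3 is not broken down here. Between compound 3 and compound 1 the one change is bromo in place of fluoro on an aromatic carbon, and it made the step of a number 7.6 percentage points higher from compound 3 to compound 1 (within the scatter).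

Compound 4, `O=C1NC(=S)/C(=C/c2cccc(Br)c2)S1`, is not yet measured. It differs from compound 2 by bromo in place of fluoro on an aromatic carbon. This is the same kind of change as that from compound 3 to compound 1, but not the same: there the place was para to a group of 8 heavy atoms, here it is meta to a group of 8 heavy atoms.

The expected step from compound 2 to compound 4 is a number 3.2 percentage points higher from compound 2 to compound 4 (within the scatter), resting on the step from compound 3 to compound 1 of a number 7.6 percentage points higher from compound 3 to compound 1 (within the scatter), which lay within the scatter. For compound 4 the estimated value in this assay is 4%, between -8% and 16%.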

Compound 4, percent growth inhibition at one concentration: -5.3%
Compound 4: the middle estimate sits 9.3 percentage points above what was measured; measured number inside the range.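

In this assay, bromo in place of fluoro on an aromatic carbon gave a number 6.1 percentage points lower from compound 2 to compound 4 (within the scatter). Set beside the earlier step, the same change does not read differently on the two cores: the same change on two cores in this assay, a number 7.6 percentage points higher (within the scatter) from compound 3 to compound 1 and a number 6.1 percentage points lower (within the scatter) from compound 2 to compound 4, 13.8 percentage points apart, within the scatter of two such steps. The two steps point in opposite directions, but that is no evidence of a real reversal between the cores; equally, it does not show that the change carries over with a fixed size or direction, or that the two places on the ring are equivalent, as each step lies within the scatter and each place was tested only once.

The compounds shown carry only a single fluoro or bromo on the aromatic ring, which leaves open whether an amine, a carboxylic acid or a longer chain at these places would move the result in this assay beyond the scatter. Also open is how any of these compounds would behave at other concentrations, as the read-out here comes from one concentration only.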